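The source may hold more compounds than are shown below. What is called first, only, known or untested is meant among the compounds shown, and "the series" means these compounds.

Measured so far, in a functional assay on HeLa cells (Homo sapiens) for inhibition, read by CCK-8 assay, with a stated time of 48 h; a lower number here means a stronger inhibitor, a higher number a weaker inhibitor:

Compound 1 `Fc1ccc(C2=NN(C3=NC(c4ccccc4)CS3)C(c3ccc4ccccc4c3)C2)cc1`, 9730 nM
Compound 2 `O=C1CSC(N2N=C(c3ccc(Br)cc3)CC2c2ccc3ccccc3c2)=N1`, 4220 nM
Compound 3 `Brc1ccc(C2=NN(C3=NC(c4ccccc4)CS3)C(c3ccc4ccccc4c3)C2)cc1`, 4960 nM

Compound 3 differs from compound 1 by fluoro in place of bromo on an aromatic carbon; the step of a 2.0-fold higher number from compound 3 to compound 1 (0.29 log units; within the scatter). Compound 2 stands lowest of the three, but its gap to compound 3 is within the scatter, so no order can be read between those two. The two cores differ as given by a group of 6 heavy atoms (3 carbon, 1 nitrogen, 1 oxygen, 1 sulfur; one five-membered non-aromatic ring with 2 hetero atoms) in place of a group of 11 heavy atoms (9 carbon, 1 nitrogen, 1 sulfur; one five-membered non-aromatic ring with 2 hetero atoms, one six-membered aromatic ring of carbon only), on an amine nitrogen in a ring, with step a 1.2-fold higher number from compound 2 to compound 3 (0.07 log units; within the scatter).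

Compound 4 `O=C1CSC(N2N=C(c3ccc(F)cc3)CC2c2ccc3ccccc3c2)=N1` is not yet measured. It differs from compound 2 by fluoro in place of bromo on an aromatic carbon, the same kind of change as from compound 3 to compound 1, and the place is described in the same words. Within the data shown here, the expected step in this assay is a 1.5-fold higher number from compound 2 to compound 4 (0.19 log units; within the scatter), resting on the single earlier step of a 2.0-fold higher number from compound 3 to compound 1 (0.29 log units; within the scatter), which is itself within the scatter. Compound 4 is therefore estimated at 6500 nM, between 2500 nM and 16000 nM.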

Compound 4, half-maximal inhibitory concentration: 9170 nM
Beside the measured number, compound 4's estimate is 1.4-fold (0.15 log units) below it; the range from low to high includes it.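

In this assay, the change from 4-bromophenyl to 4-fluorophenyl gives a 2.2-fold higher number from compound 2 to compound 4 (0.34 log units; beyond the scatter), and this step agrees with the one on the other core: the same change on two cores in this assay, a 2.0-fold higher number (0.29 log units; within the scatter) from compound 3 to compound 1 and a 2.2-fold higher number (0.34 log units; beyond the scatter) from compound 2 to compound 4, 1.1-fold (0.04 log units) apart, within the scatter of two such steps. The change of core with the fluoro group in place gives a 1.1-fold lower number from compound 1 to compound 4 (0.03 log units; within the scatter), and this agrees with the change of core with the bromo group in place: the same change on two cores in this assay, a 1.2-fold higher number (0.07 log units; within the scatter) from compound 2 to compound 3 and a 1.1-fold higher number (0.03 log units; within the scatter) from compound 4 to compound 1, 1.1-fold (0.04 log units) apart, within the scatter of two such steps. The halogen change therefore carries across these two cores without a readable difference in step size, but this rests on a single comparison of two cores and one halogen pair, and it shows nothing about other cores.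

Going by these compounds, whether the step holds for chloro, methoxy or an amine at that place remains open. Also open is how a group carrying a carboxylic acid would compare with the two groups shown on the amine nitrogen in a ring.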